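This account rests on a few compounds, and the source may have more. Where it says the series, first, only, none or still open, it means among the compounds named here.

Series notes. The measured set comprises compound 1 `C=CC1=C(C(=O)NCc2ccc(Cl)cc2)C(c2ccc(OC)c(OC)c2)OC1`, compound 2 `C=CC1=C(C(=O)NCCCCC)C(c2ccc(OC)cc2)OC1` and compound 3 `C=CC1=C(C(=O)Nc2ccccc2)C(c2ccc(Cl)c(Cl)c2)OC1`, all read in a functional assay on A549 cells (Homo sapiens) for cytotoxicity, read by MTT assay, with a stated time of 24 h; a lower number here means a stronger inhibitor, a higher number a weaker inhibitor. For compound 1 the value is a limit of the assay and not a number: compound 1 gives > 100000 nM. Compound 3 likewise sits at a limit, compound 3 giving > 100000 nM. Only compound 2 returns a number, compound 2 giving 36500 nM. Going by the values given here, compound 1 therefore stands at the limit, where two of the three values sit (the limit of > 100000 nM in this assay, at which 2 of the 3 values shown sit), and no step between measured compounds is available.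

Compound 4 `C=CC1=C(C(=O)NCc2ccc(Cl)cc2)C(c2ccc(OC)cc2)OC1` is the next member. It differs from compound 1 by hydrogen in place of methoxy on an aromatic carbon. Compound 4 thereby carries the same aromatic substitution as compound 2, while keeping the amide of compound 1. With compound 1 at a limit, the step is expected to come out as none beyond the scatter, or at most as a modest gain toward the number seen for compound 2. For compound 4 the expected step is an at least 1.1-fold lower number from compound 1 to compound 4 (0.04 log units; that floor lies within the scatter). For compound 4 the estimate is 90000 nM, expected to lie between 30000 nM and 300000 nM, with a fair chance that the assay again reports only a limit.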

Compound 4, half-maximal inhibitory concentration: > 100000 nM
Compound 4 gave a limit, no number; the forecaster's own chance of this, stated with the estimate: 55%; middle value at least 1.1-fold (0.04 log units) away from the limit.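

In this assay compound 4 is a limit of the assay and not a number: > 100000 nM. Taking off the methoxy therefore brings no number into this amide pair, the step between the two limits cannot be read, and the limit now holds most of the series: the limit of > 100000 nM in this assay, at which 3 of the 4 values shown sit.

Going by these compounds alone, with the aromatic substitution held constant, the amide side gives the first readable step, with 4-chlorophenyl in place of butyl on the saturated chain carbon bound to the amide-type nitrogen: an at least 2.7-fold higher number from compound 2 to compound 4 (0.43 log units; beyond the scatter).

On these data alone, how the methoxy acts at this position remains open while both partners sit at the limit. Also open, as far as these compounds go, is whether an amine or a carboxylic acid in place of the 4-chlorophenyl, or a chain longer than the butyl, would give a lower number than compound 2 gives.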